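A Second Methoxy Added to Compound 1

This account rests on a few compounds, and the source may have more. Where it says the series, first, only, none or still open, it means among the compounds named here.

Among the compounds with values here, in a functional assay on KB cells (Homo sapiens) for antiproliferative activity, read by sulforhodamine B assay, with a stated time of 72 h (a lower number here means a stronger inhibitor, a higher number a weaker inhibitor), compound 1 (`COc1cccc(/C=C2\CCC=CC2=O)c1`) gives 1550 nM and holds the lower of the two numbers measured so far. Compound 2 (`COc1cccc(/C=C2\CCC=CC2=O)c1OC`) gives 3850 nM in the same read-out. Compound 3 (`COc1cc(/C=C2\CCC=CC2=O)cc(OC)c1`) differs from compound 1 by this change: methoxy in place of hydrogen on an aromatic carbon. In words, a methoxy stands in place of hydrogen on an aromatic carbon. Within the data shown here, only one measured step bears on it, the same kind of change made at another place on the ring: a 2.5-fold higher number from compound 1 to compound 2 (0.40 log units; beyond the scatter). That step is modest but beyond the scatter, and a single example gives only a loose guide. A rise of similar or smaller size is therefore expected in this assay, and the estimated step is a 1.5-fold higher number from compound 1 to compound 3 (0.19 log units; within the scatter) as the central expectation. For compound 3 the expected value is 2400 nM, with an estimated range from 1000 nM to 5500 nM.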

Compound 3, half-maximal inhibitory concentration: 3630 nM
Compound 3: the middle estimate sits 1.5-fold (0.18 log units) below what was measured, and the stated range covers the measured number.
By their numbers in this assay, from the lowest: compound 1; then compounds 3 and 2 (each within the scatter of the next).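

In this assay, methoxy in place of hydrogen on an aromatic carbon, here meta to a methoxy group and meta to a group of 8 heavy atoms, brings a 2.3-fold higher number from compound 1 to compound 3 (0.37 log units; beyond the scatter) and so lies beyond the scatter. The earlier compounds showed a rise of this kind at one place on the ring only; this step shows that the number also rises at a second place, so both additions of a methoxy to compound 1 shown here go the same way, and neither goes against the other. No measurement at hand explains the rise at this position. Still open, going by these compounds, is how a hydroxy group, a chlorine atom or an amine would read at this place. Also open, on these data alone, is whether a longer chain, such as ethoxy, would follow methoxy.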